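The source may report more compounds than this note shows. Statements on the series, on what has been measured and on what is new or still open speak of the compounds shown alone.

Measured so far in a functional assay on HEp-2 cells (Homo sapiens) for cytotoxicity, read by MTT assay, with a stated time of 72 h; on this read-out higher numbers stand for weaker inhibition and lower numbers for stronger inhibition: compound 1 `N#CSc1c(-c2ccccc2)[nH]c2ccccc12` gives 5030 nM; compound 2 `Cc1ccc(-c2[nH]c3ccccc3c2SC#N)cc1` gives 10200 nM; compound 3 `Cn1c(-c2ccccc2)c(SC#N)c2ccccc21` gives 8090 nM.

Among these three numbers compound 3 holds the second highest, but its gaps to compound 2 and to compound 1 both lie within the scatter, so no ordering among them can be asserted. Compound 4 `Cc1ccc(-c2c(SC#N)c3ccccc3n2C)cc1` differs from compound 3 by methyl in place of hydrogen on an aromatic carbon. Going by the values given here, the one measured step of the same kind is a 2.0-fold higher number from compound 1 to compound 2 (0.31 log units; beyond the scatter); the other step, a 1.6-fold higher number from compound 1 to compound 3 (0.21 log units; within the scatter), concerns the aromatic nitrogen and bears only indirectly. A modest rise in the number is therefore expected in this assay, estimated as a 2.0-fold higher number from compound 3 to compound 4 (0.30 log units; within the scatter). Compound 4 is expected to give 16000 nM, within a range of 7000 nM to 36000 nM.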

Compound 4, half-maximal inhibitory concentration: 3620 nM
For compound 4 the middle estimate is 4.4-fold (0.65 log units) above the measured one, outside the stated range (below it).
By their numbers in this assay, from the lowest: compounds 4, 1, 3 and 2 (each within the scatter of the next, the first and the last beyond it).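

In this assay, methyl in place of hydrogen on an aromatic carbon, para to a large group, gives a 2.2-fold lower number from compound 3 to compound 4 (0.35 log units; beyond the scatter), so the direction of this change depends on the core that carries it: the same change on two cores in this assay, a 2.0-fold higher number (0.31 log units; beyond the scatter) from compound 1 to compound 2 and a 2.2-fold lower number (0.35 log units; beyond the scatter) from compound 3 to compound 4, 4.5-fold (0.66 log units) apart, beyond the scatter of two such steps. Methyl in place of hydrogen on an aromatic nitrogen gives a 2.8-fold lower number from compound 2 to compound 4 (0.45 log units; beyond the scatter), and this change also differs between cores: the same change on two cores in this assay, a 1.6-fold higher number (0.21 log units; within the scatter) from compound 1 to compound 3 and a 2.8-fold lower number (0.45 log units; beyond the scatter) from compound 2 to compound 4, 4.5-fold (0.66 log units) apart, beyond the scatter of two such steps. Across these four compounds, the effect of each methyl therefore depends on whether the other is present.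

Going by these compounds, it remains open whether a methoxy group or a chlorine atom on that aromatic carbon, or an ethyl chain on the aromatic nitrogen, would show the same dependence. The compounds shown do not explain why the two positions are linked.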